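The compounds below may be only part of what the source reports. "The series", "measured", "known", "first", "only" and "open" are said of these compounds alone.

The study concerns three measured amides on a shared core. Compound 1 `CC(C)n1ncc2c(C(=O)Nc3cccnc3)cccc21` gives > 40000 nM in a functional assay on MGC-803 cells (Homo sapiens) for inhibition, read by MTT assay, with a stated time of 72 h (a higher number here means a weaker inhibitor, a lower number a stronger inhibitor), and this is a limit of the assay rather than a number. Compound 2 `CC(C)n1ncc2c(C(=O)NC3CCCC3)cccc21` likewise gives > 40000 nM in this assay, again a limit. The step that the two limits leave unreadable from compound 1 to compound 2 can accordingly not be read. Compound 3 `CC(C)n1ncc2c(C(=O)NCc3cn(-c4ccc(F)cc4)nn3)cccc21` stands at > 40000 nM in this assay, which is also a limit. Among the compounds with values here, all three measured values thus sit at the limit of > 40000 nM in this assay, at which 3 of the 3 values shown sit; compound 3 stands nowhere apart from compounds 1 and 2, and no measured step in the set can be sized.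

Compound 4 `CC(C)n1ncc2c(C(=O)NCc3cn(-c4ccc(C(F)(F)F)cc4)nn3)cccc21` is not yet measured. It differs from compound 3 by trifluoromethyl in place of fluoro on an aromatic carbon. Within the data shown here, the one measured step, from compound 1 to compound 2, touches a different part of the molecule and is unreadable, so it offers no guide on direction or size, and no step on the ring carrying the fluoro has been measured. With every value at the limit, the expected step of a number no higher from compound 3 to compound 4 (the limit leaves the size open) means that compound 4 is expected to reach no readable value in this assay either. Compound 4 is estimated at 40000 nM in this assay, within a range of 10000 nM to 150000 nM, most probably reported again as a limit.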

Compound 4, half-maximal inhibitory concentration: > 40000 nM
Compound 4: no number, only a limit; the forecaster's own chance of this, stated with the estimate: 80%; the middle value sits exactly at the limit.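

Compound 3 and compound 4 each give only a limit in this assay, so the exchange of fluoro for trifluoromethyl cannot be read as a step: the limit of > 40000 nM in this assay, at which 4 of the 4 values shown sit.

The compounds shown leave open how strongly any of these amides inhibits in this assay, and whether changing the group on the aromatic ring alters that inhibition at all.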